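From Acetamido to Methyl((trifluoromethyl)carbonyl)amino

A few compounds are considered here, and "the series" means these few. Any claim that something is new, unique, unknown or untested is made for them only; others in the source may bear on it.

In a functional assay on the whole organism with Rattus norvegicus as the target (a lower number here means that less compound is needed, a higher number that more compound is needed for the effect), compound 1 (`COc1cc(N(C)C)c(Cl)cc1C(=O)NC1CCN(Cc2ccccc2)C1`) gives 0.12 mg/kg with a dimethylamino group on the aromatic ring. Compound 2 (`COc1cc(NCc2ccccc2)c(Cl)cc1C(=O)NC1CCN(Cc2ccccc2)C1`) carries benzylamino in that place and gives > 30 mg/kg as a limit of the assay, not a number. Compound 3 (`COc1cc(NC(C)=O)c(Cl)cc1C(=O)NC1CCN(Cc2ccccc2)C1`) carries acetamido there and gives 1.8 mg/kg as the higher of the two true numbers.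

Every measured change at this spot was large. Benzylamino in place of dimethylamino gave an at least 250-fold higher number from compound 1 to compound 2 (2.39 log units; beyond the scatter) in the read-out. Acetamido in place of dimethylamino gave a 15-fold higher number from compound 1 to compound 3 (1.18 log units; beyond the scatter) in the read-out. Acetyl in place of benzyl gave an at least 16-fold lower number from compound 2 to compound 3 (1.22 log units; beyond the scatter) in the read-out.

Compound 4 (`COc1cc(N(C)C(=O)C(F)(F)F)c(Cl)cc1C(=O)NC1CCN(Cc2ccccc2)C1`) is still unmeasured. In it, methyl((trifluoromethyl)carbonyl)amino stands in place of acetamido on an aromatic carbon (methyl((trifluoromethyl)carbonyl)amino in place of acetamido on an aromatic carbon). Its nitrogen carries a methyl group, as in compound 1, and a carbonyl, as in compound 3, so it shares features with both. Within the data shown here, no measured step makes this exact swap, and the steps at this spot warn that a sizeable move in either direction remains possible. The most likely outcome is therefore an expected 1.5-fold lower number from compound 3 to compound 4 (0.18 log units; within the scatter) in this assay without a firm direction. For compound 4 the estimated value is 1.2 mg/kg (expected range 0.2 mg/kg to 8 mg/kg).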

Compound 4, dose for half-maximal effect: 0.3 mg/kg
Compound 4: the middle estimate sits 4.0-fold (0.60 log units) above what was measured; low and high end bracket the measured number.
By their numbers in this assay, from the lowest: compound 1; then compound 4; then compound 3. At a limit, above all of these: compound 2.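

In this assay, methyl((trifluoromethyl)carbonyl)amino in place of acetamido gives a 6.0-fold lower number from compound 3 to compound 4 (0.78 log units; beyond the scatter) and so shows that a carbonyl on this nitrogen is compatible with a much lower dose than compound 3 alone suggested. Compound 1 still needs the least compound, since (trifluoromethyl)carbonyl in place of methyl gives a 2.5-fold higher number from compound 1 to compound 4 (0.40 log units; beyond the scatter) in this assay, and across all the compounds shown, the two with no hydrogen on this nitrogen, compound 1 and compound 4, have the lowest numbers. Compound 2 gives only a limit and not a true number, so the step of an at least 100-fold lower number from compound 2 to compound 4 (2.00 log units; beyond the scatter) fixes only a minimum size for the gap: the limit of > 30 mg/kg in this assay, at which 1 of the 4 values shown sits.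

The step to compound 4 adds a methyl on the nitrogen and three fluorines at once, so the compounds shown cannot say which of the two changes goes with the lower number. The methyl(acetyl)amino group, with the nitrogen methyl but no fluorine, and the trifluoroacetamido group, with fluorine but the amide hydrogen kept, would separate these two changes.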